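A few compounds are considered here, and "the series" means these few. Any claim that something is new, unique, unknown or untested is made for them only; others in the source may bear on it.

Measured compounds:
compound 1 `COc1ncc(-c2ccc3ncnc(Nc4ccc(OCCCO)nc4)c3c2)cc1NS(=O)(=O)c1ccc(F)cc1F`: 6120 nM
compound 2 `CCCCS(=O)(=O)Nc1cc(-c2ccc3ncnc(Nc4ccc(OCCO)nc4)c3c2)cnc1OC`: > 20000 nM

Within the data shown here, in a functional assay on MCF7 cells (Homo sapiens) for antiproliferative activity, read by sulforhodamine B assay, with a stated time of 72 h (on this read-out lower numbers stand for stronger inhibition and higher numbers for weaker inhibition), compound 1 gives 6120 nM, the only actual number among the two values shown. Compound 2 returns only a limit, > 20000 nM, in this assay; this is the limit of > 20000 nM in this assay, at which 1 of the 2 values shown sits, and it is a limit of the assay rather than a number. Among the measured compounds shown here, no pair of measured compounds differs in one place, so no measured step is available.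

Compound 3 `COc1ncc(-c2ccc3ncnc(Nc4cnn(CC(=O)O)c4)c3c2)cc1NS(=O)(=O)c1ccc(F)cc1F` has not yet been measured. It differs from compound 1 in 1-(carboxymethyl)-1H-pyrazol-4-yl in place of 6-(3-hydroxypropoxy)pyridin-3-yl on a nitrogen on an aromatic ring. Nothing measured here speaks to what this exchange does in this assay. For the measured compounds named here, with compound 1 as the only number, the expectation is a step of a 1.6-fold higher number from compound 1 to compound 3 (0.21 log units; within the scatter), most likely toward weaker inhibition but not clearly beyond the scatter of repeated runs. Compound 3 is therefore estimated at 10000 nM in this assay, with a plausible range from 3000 nM to 30000 nM, and a real chance that the assay reports only a limit.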

Compound 3, half-maximal inhibitory concentration: 700 nM
Estimate against measurement, compound 3: 14-fold (1.15 log units) above, and the stated range ends above it.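

In this assay, the exchange of 6-(3-hydroxypropoxy)pyridin-3-yl for 1-(carboxymethyl)-1H-pyrazol-4-yl on the nitrogen on an aromatic ring gives an 8.7-fold lower number from compound 1 to compound 3 (0.94 log units; beyond the scatter), with the rest of the structure unchanged. Among these compounds, this is the first step between measured compounds that differ in one place, and it shows that the read-out responds to the group at this position by more than the usual scatter, which the earlier compounds could not show. Nothing measured here gives a reason for this step, even though the counts of hydrogen-bond donors and acceptors in the two groups are the same.

The exchange replaces the six-membered aromatic ring and its chain together, so the step cannot be divided between the five-membered aromatic ring and the carboxymethyl group. On these data alone, it remains open whether that ring would keep the lower number with a methyl ester, a primary amide, a hydroxyethyl chain or a longer chain ending in a carboxylic acid, and whether the step would carry over to a core bearing a different sulfonamide group.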